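Amide variation on the shared core of compound 1

The compounds below may be only part of what the source reports. "The series", "measured", "known", "first", "only" and "open" are said of these compounds alone.

Measured so far in a functional assay on NCI-H2228 cells (Homo sapiens) for antiproliferative activity, read by MTT assay, with a stated time of 72 h; on this read-out higher numbers stand for weaker inhibition and lower numbers for stronger inhibition:
compound 1 `COC(=O)c1cccn1-c1ccc(Nc2ncc(Cl)c(Nc3ccccc3NS(C)(=O)=O)n2)c(OC)c1` gives 950 nM
compound 2 `COc1cc(-n2cccc2C(=O)N2CCCCC2)ccc1Nc1ncc(Cl)c(Nc2ccccc2NS(C)(=O)=O)n1` gives 630 nM
compound 3 `COc1cc(-n2cccc2C(=O)N2CCCC2)ccc1Nc1ncc(Cl)c(Nc2ccccc2NS(C)(=O)=O)n1` gives 600 nM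

Compound 3 has the lowest of the three numbers in this assay, but its separation from the others is small: a 1.1-fold lower number from compound 2 to compound 3 (0.02 log units; within the scatter), and a 1.6-fold lower number from compound 1 to compound 3 (0.20 log units; within the scatter). The three compounds differ only in the group on the carbonyl carbon attached to the aromatic carbon, and none of the swaps made there has moved the number beyond the scatter.

Compound 4 `COc1cc(-n2cccc2C(=O)N2CCC(C)CC2)ccc1Nc1ncc(Cl)c(Nc2ccccc2NS(C)(=O)=O)n1` is not yet measured. It differs from compound 3 as follows: 4-methylpiperidin-1-yl in place of pyrrolidin-1-yl on a carbonyl carbon. Going by these compounds, the step that bears most directly on it is the one from a five-membered to a six-membered ring, a 1.1-fold lower number from compound 2 to compound 3 (0.02 log units; within the scatter), which was within the scatter; the methyl on the six-membered ring is untested here, so no further shift can be read from the series. The expected step of a 1.1-fold higher number from compound 3 to compound 4 (0.03 log units; within the scatter) is therefore none beyond the scatter. Compound 4 is estimated at 650 nM, with a range from 300 nM to 1400 nM.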

Compound 4, half-maximal inhibitory concentration: 1050 nM
The estimate for compound 4 lay 1.6-fold (0.21 log units) below the measured number, within the range that was stated.
By their numbers in this assay, from the lowest: compounds 3, 2, 1 and 4 (each within the scatter of the next).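

In this assay the methyl in place of hydrogen on a saturated ring carbon gives a 1.7-fold higher number from compound 2 to compound 4 (0.22 log units; within the scatter) and is the only substitution on the saturated ring shown so far. The wider swaps give a 1.8-fold higher number from compound 3 to compound 4 (0.24 log units; within the scatter) and a 1.1-fold higher number from compound 1 to compound 4 (0.04 log units; within the scatter) and all three steps stay within the scatter. The carbonyl carbon therefore holds methoxy, pyrrolidin-1-yl, piperidin-1-yl and 4-methylpiperidin-1-yl, the last with 7 heavy atoms, with no step beyond the scatter, and no measurement available bears on the reason for these numbers.

Still open, going by these compounds, is whether an amide ring with a second hetero atom, such as morpholin-4-yl or 4-methylpiperazin-1-yl, would move the number beyond the scatter. On these data alone, a carboxylic acid at this place, or a hydroxyl on the saturated ring, also remains open.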